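Moving the fluorine around the benzyl ring

A few compounds are considered here, and "the series" means these few. Any claim that something is new, unique, unknown or untested is made for them only; others in the source may bear on it.

In a functional assay on SW-620 cells (Homo sapiens) for inhibition, read by MTT assay, with a stated time of 48 h (a lower number here means a stronger inhibitor, a higher number a weaker inhibitor), compound 1 `Cc1ccc(NC(=O)NC(=O)c2ccc(OCc3ccc(C(F)(F)F)cc3)cc2)cc1-c1nc2ccccc2[nH]1` gives 15300 nM. Among the compounds with values here, compound 2 `Cc1ccc(NC(=O)NC(=O)c2ccc(OCc3ccccc3F)cc2)cc1-c1nc2ccccc2[nH]1` gives 4110 nM in this assay, the lowest of the two numbers measured so far. Within the data shown here, the only measured step, a 3.7-fold lower number from compound 1 to compound 2 (0.57 log units; beyond the scatter), concerns a different exchange of the whole benzyl group. Compound 3 `Cc1ccc(NC(=O)NC(=O)c2ccc(OCc3cccc(F)c3)cc2)cc1-c1nc2ccccc2[nH]1` differs from compound 2 by 3-fluorophenyl in place of 2-fluorophenyl on a saturated chain carbon bound to an oxygen on an aromatic ring. Among the measured compounds shown here, no measured step bears directly on this change, so the expectation is a step of a 1.1-fold higher number from compound 2 to compound 3 (0.04 log units; within the scatter), nothing beyond the scatter. Compound 3 is therefore estimated at 4500 nM in this assay, with a range from 1800 nM to 11000 nM.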

Compound 3, half-maximal inhibitory concentration: 39600 nM
The estimate for compound 3 lay 8.8-fold (0.94 log units) below the measured number; measured number above the stated range.
By their numbers in this assay, from the lowest: compound 2; then compound 1; then compound 3.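

Moving the fluorine is not a neutral exchange at this position, even though the atoms stay the same: in this assay the change from 2-fluorophenyl to 3-fluorophenyl gives a 9.6-fold higher number from compound 2 to compound 3 (0.98 log units; beyond the scatter) and is the largest step among these compounds. The 3-fluorophenyl group also compares poorly with 4-(trifluoromethyl)phenyl, with a 2.6-fold higher number from compound 1 to compound 3 (0.41 log units; beyond the scatter) at the same place. Nothing measured here accounts for the gap between the two fluorine placements. The compounds shown leave open whether a plain phenyl, or a chlorine or methoxy group in place of the fluorine, would follow the 2-fluorophenyl number or the 3-fluorophenyl number.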